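Acylating the Hydroxyl of Compound 2: An Expectation

The source may report more compounds than this note shows. Statements on the series, on what has been measured and on what is new or still open speak of the compounds shown alone.

Measured so far in an assay on nucleic acid for inhibition of Nucleic Acid, read by fluorescence, tested at 100 uM; on this read-out higher numbers stand for more inhibition at the one concentration tested (going by the name of the read-out) and lower numbers for less inhibition:
Compound 1 `CCCCN(CCCC)Cc1cn(CC(O)COCc2ccccc2)nn1`: 6%
Compound 2 `OC1CCCCC1n1cc(CN2CCN(c3ccccc3)CC2)nn1`: 47%
Compound 3 `CCCCC(O)Cn1cc(CN2CCN(c3ccccc3)CC2)nn1`: 47%

Compound 2 stands level with compound 3 at the digits shown, and these two share the highest reading of the three; compound 1, built on a different core, sits well below them, beyond the scatter. The one step that joins two of these compounds in a single place, no change at the digits printed from compound 2 to compound 3 (within the scatter), exchanges the group on the aromatic nitrogen and leaves the reading unchanged.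

Compound 4 `O=C(COc1ccccc1)OC1CCCCC1n1cc(CN2CCN(c3ccccc3)CC2)nn1` differs from compound 2 in another place altogether: (phenoxymethyl)carbonyl in place of hydrogen on an oxygen on a saturated carbon. Among the compounds with values here, no measured step touches this oxygen, so the step from compound 2 to compound 3 bears on the new change only in showing that an alteration of the hydroxyalkyl arm on the shared core left the reading level. Nothing measured tells whether a larger substituent on that oxygen will leave the number level in the same way.

The reading for compound 4 is therefore expected to land near that of compound 2, with a step of a number 7 percentage points lower from compound 2 to compound 4 (within the scatter), though a drop cannot be excluded. Compound 4 is estimated at 40%, within a range from 15% to 65%.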

Compound 4, a percentage reported as inhibition, at one concentration (the size of the read-out at that concentration, not a potency): 37%
Compound 4: middle estimate off by 3 percentage points, on the high side; low and high end bracket the measured number.
By their numbers in this assay, from the lowest: compound 1; then compounds 4, 2 and 3 (each within the scatter of the next).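

Within the data shown here, on the oxygen of the saturated ring carbon, (phenoxymethyl)carbonyl in place of hydrogen gives a number 10 percentage points lower from compound 2 to compound 4 (within the scatter) in this assay, the first measured change at this position. On the shared core, therefore, a reading of this size does not depend on a free hydroxy at this place, and it stays within the scatter even when hydroxy gives way to ((phenoxymethyl)carbonyl)oxy, which brings in 10 heavy atoms and a six-membered aromatic ring of carbon only. Nothing given here explains why the reading holds when this oxygen is acylated.

With only one group on this oxygen among the compounds shown, it remains open whether a small acetyl, a longer alkyl chain, a simple methyl ether, or an acyl group carrying an amine or a carboxylic acid would also leave the reading within the scatter of compound 2. As far as these compounds go, it is equally open whether (phenoxymethyl)carbonyl on the oxygen of the 2-hydroxyhexyl arm of compound 3 would behave as it does on the 2-hydroxycyclohexyl arm of compound 2.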